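Benzyloxy for benzyl on the cinnamic acid core

A few compounds are considered here, and "the series" means these few. Any claim that something is new, unique, unknown or untested is made for them only; others in the source may bear on it.

Compound 1 `O=C(O)/C=C/c1ccc(Cn2ccnc2)cc1OCCc1ccc2ccccc2c1` gives 50 nM in an in vitro functional assay on CHO cells for antagonist activity at prostaglandin E2 receptor EP3 subtype (Mus musculus); on this read-out lower numbers stand for stronger inhibition and higher numbers for weaker inhibition. Compound 2 `O=C(O)/C=C/c1ccc(Cc2ccccc2)cc1OCCc1ccc2ccccc2c1` gives 400 nM in this assay, the higher of the two numbers; the step of an 8.0-fold higher number from compound 1 to compound 2 (0.90 log units; beyond the scatter) separates them. Compound 3 `O=C(O)/C=C/c1ccc(OCc2ccccc2)cc1OCCc1ccc2ccccc2c1` carries the change (benzyloxy in place of benzyl on an aromatic carbon). Among the compounds with values here, no measured step swaps a benzyl for a benzyloxy; the only step in hand, an 8.0-fold higher number from compound 1 to compound 2 (0.90 log units; beyond the scatter), concerns the group on the chain carbon and does not bear on an inserted oxygen. With no guide, the step of no change at the digits printed from compound 2 to compound 3 (within the scatter) is expected to stay within the scatter. Compound 3 is therefore estimated at 400 nM, with a range from 100 nM to 1600 nM.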

Compound 3, half-maximal inhibitory concentration: 1500 nM
For compound 3 the middle estimate is 3.8-fold (0.57 log units) below the measured one; the measured number falls inside the stated range.
By their numbers in this assay, from the lowest: compound 1; then compound 2; then compound 3.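

At this position, on an aromatic carbon para to a 2-carboxyethenyl group, the read-out in this assay responds to the link as well as to the terminal group: benzyloxy in place of benzyl gives a 3.8-fold higher number from compound 2 to compound 3 (0.57 log units; beyond the scatter). Benzyloxy in place of (1H-imidazol-1-yl)methyl gives a large step, a 30-fold higher number from compound 1 to compound 3 (1.48 log units; beyond the scatter). Nothing in hand accounts for either step.

From the compounds shown here alone, it remains open whether a longer chain or an amine nitrogen in the link would give a similar number. Also open, going by these compounds, is how 1H-imidazol-1-yl behaves when attached through an oxygen-containing link.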